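Chain extension on the amine side of compound 2

A few compounds are considered here, and "the series" means these few. Any claim that something is new, unique, unknown or untested is made for them only; others in the source may bear on it.

Among the compounds with values here, in a functional assay on NCI-H460 cells (Homo sapiens) for cytotoxicity, read by MTT assay, with a stated time of 72 h (a lower number here means a stronger inhibitor, a higher number a weaker inhibitor), compound 2 `CN(C)CCNc1nc(N/N=C/c2nccn2Cc2ccc(F)cc2)nc2ccccc12` gives 1050 nM, the second highest of the three numbers so far. Compound 3 `CN(C)CCNc1nc(N/N=C/c2nccn2Cc2cccc(Cl)c2Cl)nc2ccccc12` gives 870 nM, and the step of a 1.2-fold lower number from compound 2 to compound 3 (0.08 log units; within the scatter) lies within the scatter. Compound 1 `Cc1ccc(Cn2ccnc2/C=N/Nc2nc(NCCN(C)C)c3ccccc3n2)cc1` gives 4200 nM; the steps of a 4.0-fold lower number from compound 1 to compound 2 (0.60 log units; beyond the scatter) and a 4.8-fold lower number from compound 1 to compound 3 (0.68 log units; beyond the scatter) both concern the aryl group on the saturated chain carbon bound to an aromatic nitrogen. Compound 4 `CN(C)CCCNc1nc(N/N=C/c2nccn2Cc2ccc(F)cc2)nc2ccccc12` differs from compound 2 elsewhere: (dimethylamino)methyl in place of dimethylamino on a saturated chain carbon, two bonds along the chain from a nitrogen on an aromatic ring. Within the data shown here, none of the measured steps touches this region, and no measured precedent for the change exists. The expectation is therefore a step of no change at the digits printed from compound 2 to compound 4 (within the scatter), within the scatter. Compound 4 is accordingly estimated at 1050 nM in this assay, in a range from 400 nM to 2800 nM.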

Compound 4, half-maximal inhibitory concentration: 640 nM
Compound 4: middle estimate off by 1.6-fold (0.22 log units), on the high side, within the range that was stated.
By their numbers in this assay, from the lowest: compounds 4, 3 and 2 (each within the scatter of the next); then compound 1.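

In this assay, the amine side of the series now has its first measured step (a 1.6-fold lower number from compound 2 to compound 4 (0.22 log units; within the scatter)), from the (2-(dimethylamino)ethyl)amino chain to the (3-(dimethylamino)propyl)amino chain. With the 4-fluorophenyl group held constant, this position accepts the longer chain with the terminal dimethylamino group kept, and no change can be read. No measured evidence bears on the reason for this. Still open, from the compounds shown here alone, is whether a 4-(dimethylamino)butyl chain behaves the same way. Also open, going by these compounds, is whether a terminal morpholine or piperidine can replace dimethylamino on either chain.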